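Chain length and carbamate removal on the shared core

A few compounds are considered here, and "the series" means these few. Any claim that something is new, unique, unknown or untested is made for them only; others in the source may bear on it.

Within the data shown here, in an assay on HEK293 cells for displacement of a labelled ligand from NPC1-like intracellular cholesterol transporter 1 (Homo sapiens) (on this read-out higher numbers stand for weaker inhibition and lower numbers for stronger inhibition), compound 1 `CC(C)(C)OC(=O)NCCCCCNC(=O)CN1CN(c2ccccc2)C2(CCN(C(=O)c3ccc(C(C)(C)C)cc3)CC2)C1=O` gives 13700 nM and compound 2 `CC(C)(C)OC(=O)NCCNC(=O)CN1CN(c2ccccc2)C2(CCN(C(=O)c3ccc(C(C)(C)C)cc3)CC2)C1=O` gives 10900 nM; the one step between them, a 1.3-fold lower number from compound 1 to compound 2 (0.10 log units; within the scatter), shows that shortening the chain by this amount leaves the read-out unchanged within the scatter. Compound 3 `CC(C)(C)OC(=O)NCCCCNC(=O)CN1CN(c2ccccc2)C2(CCN(C(=O)c3ccc(C(C)(C)C)cc3)CC2)C1=O` sits between these two in chain length, but in this assay compound 3 gives "not determined" (no result reported), so it has no number of its own in this assay. Compound 4 `CC(C)(C)c1ccc(C(=O)N2CCC3(CC2)C(=O)N(CC(=O)NCCCN)CN3c2ccccc2)cc1` differs from compound 3 by amino in place of ((tert-butoxycarbonyl)amino)methyl on a saturated chain carbon, three bonds along the chain from an amide-type nitrogen. Among the measured compounds shown here, no measured step covers the loss of the tert-butoxycarbonyl group, so the expectation rests only on compound 1 and compound 2, both weak inhibitors. Compound 4 is therefore expected to give about 12000 nM in this assay, with a range from 4000 nM to 40000 nM.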

Compound 4, half-maximal inhibitory concentration: 4200 nM
Estimate against measurement, compound 4: 2.9-fold (0.46 log units) above; the measured number falls inside the stated range.
By their numbers in this assay, from the lowest: compound 4; then compounds 2 and 1 (each within the scatter of the next).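

Ending the chain in a free amino group rather than the tert-butoxycarbonyl carbamate gives the first change beyond the scatter at this position in this assay (a 2.6-fold lower number from compound 2 to compound 4 (0.41 log units; beyond the scatter); a 3.3-fold lower number from compound 1 to compound 4 (0.51 log units; beyond the scatter)). Both steps are modest, and both also alter chain length. No data here account for the shift.

With no number for compound 3, carbamate loss and chain length remain unseparated. Also open, on these data alone, is whether a longer chain ending in an amine, or a carboxylic acid at the chain end, would lower the read-out further.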